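This account rests on a few compounds, and the source may have more. Where it says the series, first, only, none or still open, it means among the compounds named here.

Notes on the series around the shared core of compound 1 `O=c1[nH]c2ccccc2cc1/C=N/O` in a functional assay, read by spectrophotometry, with a stated time of 1 h (on this read-out higher numbers stand for weaker inhibition and lower numbers for stronger inhibition), follow. Here compound 1 gives 2010000 nM as its value. Compound 2 `O=c1[nH]c2ccccc2cc1/C=N/CCO` gives 3310000 nM and so stands within the scatter of compound 1. Compound 3 `O=c1[nH]c2ccccc2cc1/C=N/c1ccc(O)cc1` is recorded as "not active" (no number reported) with no number. Compound 4 `N/N=C/c1cc2ccccc2[nH]c1=O` differs from compound 2 as follows: amino in place of 2-hydroxyethyl on a double-bonded nitrogen with amino in place of 2-hydroxyethyl on a double-bonded nitrogen. For the measured compounds named here, the only measured step at that nitrogen is a 1.6-fold higher number from compound 1 to compound 2 (0.22 log units; within the scatter) and it is small, so no step beyond the scatter is expected in this assay for this change. Compound 3 shows that a report without a number remains possible. The estimated step is a 1.3-fold lower number from compound 2 to compound 4 (0.12 log units; within the scatter) in size. For compound 4 the expected value is 2500000 nM within an estimated range of 900000 nM to 7000000 nM overall.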

Compound 4, half-maximal inhibitory concentration: 365000 nM
For compound 4 the middle estimate is 6.8-fold (0.84 log units) above the measured one; the measured number lies below the stated range.
By their numbers in this assay, from the lowest: compound 4; then compounds 1 and 2 (each within the scatter of the next).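

In this assay the group on the double-bonded nitrogen now makes a difference: amino gives steps beyond the scatter against both earlier groups (a 9.1-fold lower number from compound 2 to compound 4 (0.96 log units; beyond the scatter); a 5.5-fold lower number from compound 1 to compound 4 (0.74 log units; beyond the scatter)), whereas hydroxy and 2-hydroxyethyl stay within the scatter of each other. 2-Hydroxyethyl and amino carry the same counts of hydrogen-bond donors and acceptors, yet the step between them lies beyond the scatter. No supporting data bear on the reason for this step. On these data alone, whether a methylamino or dimethylamino group on that nitrogen keeps the lower number remains open. Steps involving compound 3 cannot be read.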